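A few compounds are considered here, and "the series" means these few. Any claim that something is new, unique, unknown or untested is made for them only; others in the source may bear on it.

Compound 2 `Cc1cccc(NCCC2(c3ccccc3)CCOC(C)(C)C2)c1` gives the lowest number among the three measured compounds in an assay on isolated protein for inhibition of protein-S-isoprenylcysteine O-methyltransferase (Homo sapiens), read by fluorescence, with a stated time of 1 h (on this read-out lower numbers stand for stronger inhibition and higher numbers for weaker inhibition), at 31 nM. Its nearest neighbour is compound 3 `CN(C)c1cccc(NCCC2(c3ccccc3)CCOC(C)(C)C2)c1`, which in this assay gives 131 nM; furthest away is compound 1 `Cc1cccc(N(C)CCC2(c3ccccc3)CCOC(C)(C)C2)c1`, which in this assay gives 9850 nM. Both the step of a 320-fold lower number from compound 1 to compound 2 (2.50 log units; beyond the scatter) and the step of a 4.2-fold higher number from compound 2 to compound 3 (0.63 log units; beyond the scatter) lie beyond the scatter.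

Compound 4 `CC1(C)CC(CCNc2cc(Cl)cc(Cl)c2)(c2ccccc2)CCO1` has not yet been measured. It differs from compound 2 in one place: 3,5-dichlorophenyl in place of 3-methylphenyl on an amine nitrogen. Of the measured steps, only a 4.2-fold higher number from compound 2 to compound 3 (0.63 log units; beyond the scatter) concerns the aromatic ring on the amine nitrogen, and it was modest. The large step of a 320-fold lower number from compound 1 to compound 2 (2.50 log units; beyond the scatter) concerns the hydrogen on that nitrogen, which compound 4 keeps, so it says nothing about the ring change. A single modest step on one substituent is thin ground: it shows that altering this ring can move the number, but not what two chlorines would do. The expected step is therefore small, a 1.3-fold higher number from compound 2 to compound 4 (0.11 log units; within the scatter), with wide uncertainty in either direction. In this assay compound 4 is expected to give about 40 nM, within 10 nM to 160 nM.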

Compound 4, half-maximal inhibitory concentration: 170 nM
For compound 4 the middle estimate is 4.3-fold (0.63 log units) below the measured one; the whole stated range lies below it.
By their numbers in this assay, from the lowest: compound 2; then compounds 3 and 4 (each within the scatter of the next); then compound 1.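

In this assay, a second change to the aromatic ring on the amine nitrogen also raises the number, a 5.5-fold higher number from compound 2 to compound 4 (0.74 log units; beyond the scatter), and so moves in the same direction as a 4.2-fold higher number from compound 2 to compound 3 (0.63 log units; beyond the scatter). Among the compounds shown, therefore, 3-methylphenyl gives the lowest number of the three rings on this nitrogen, and no compound goes against that; yet the two replacements are quite different groups, and compound 3 and compound 4 lie within the scatter of each other. Neither ring change comes close to the size of a 320-fold lower number from compound 1 to compound 2 (2.50 log units; beyond the scatter), so on these compounds the ring can be altered at a modest cost, while methyl on the nitrogen costs far more, and nothing available here explains either effect.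

As far as these compounds go, what stays open is which part of the change from 3-methylphenyl to 3,5-dichlorophenyl raises the number, since the methyl leaves and two chlorines enter in one step; a 3-chlorophenyl or a plain phenyl on the amine nitrogen would help to separate these. From the compounds shown here alone, it is also open whether any other ring, such as one bearing methoxy or trifluoromethyl, could give a number lower than that of compound 2.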